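Swapping the ring halogen: chloro to fluoro in compound 4

The compounds below may be only part of what the source reports. "The series", "measured", "known", "first", "only" and "open" are said of these compounds alone.

Measured compounds:
Compound 1, `CS(=O)(=O)Nc1ccc(O)c2c1CCCC2c1c[nH]cn1`: 34%
Compound 2, `CS(=O)(=O)Nc1ccc(Cl)c2c1CCCC2c1c[nH]cn1`: 41%
Compound 3, `CS(=O)(=O)Nc1c(O)ccc2c1CCCC2c1c[nH]cn1`: 104%

In a functional assay on Urethra with Alpha-1A adrenergic receptor (Oryctolagus cuniculus) as the target (on this read-out higher numbers stand for larger maximal responses and lower numbers for smaller maximal responses), compound 2 sits between the other two: compound 1 lies within the scatter of it, while compound 3 lies beyond the scatter, the widest gap among the three. Compound 4, `CS(=O)(=O)Nc1ccc(F)c2c1CCCC2c1c[nH]cn1`, is the next candidate. Relative to compound 2 the change is fluoro in place of chloro on an aromatic carbon. Among the compounds with values here, the one step that speaks to this position is a number 7 percentage points higher from compound 1 to compound 2 (within the scatter), which shows that exchanging one small group for another at this carbon left the response where it was. Within the data shown here, no step compares chloro with fluoro directly, and compound 3 carries its hydroxy on a different carbon, so its high value gives no guidance here. The expectation is therefore a step of a number 1 percentage points lower from compound 2 to compound 4 (within the scatter), that is, nothing beyond the scatter in this assay. Compound 4 is estimated at 40%, with a likely range from 25% to 60%.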

Compound 4, largest response reached (reported as efficacy), in percent of the reference or control that the assay uses: 64%
Estimate against measurement, compound 4: 24 percentage points below, outside the stated range (above it).
By their numbers in this assay, from the lowest: compounds 1 and 2 (each within the scatter of the next); then compound 4; then compound 3.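

In this assay, the carbon para to a methanesulfonamido group proves sensitive to which halogen it carries: fluoro in place of chloro gives a number 23 percentage points higher from compound 2 to compound 4 (beyond the scatter), although one heavy atom replaces one heavy atom and neither group counts a hydrogen-bond donor or acceptor. Fluoro in place of hydroxy at the same carbon gives a number 30 percentage points higher from compound 1 to compound 4 (beyond the scatter), so the earlier step between hydroxy and chloro, which stayed within the scatter, did not mean that every small group at this carbon gives the same response. Nothing available explains why fluoro stands apart from the other two groups here.

Going by these compounds, what bromo, methoxy or an amine would do at this carbon stays open. So does whether fluoro in place of chloro would give a step of this size on another carbon of the shared core.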